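Dropping a Methoxy Group in a Cytotoxicity Series

The source may report more compounds than this note shows. Statements on the series, on what has been measured and on what is new or still open speak of the compounds shown alone.

Compound 2 `COc1ccc(NC(=O)Nc2cc(C)nc3ccccc23)cc1Cl` is one of three close analogues examined in an ADME assay on Raji cells (Homo sapiens) for cytotoxicity, with a stated time of 72 h; a higher number here means that more compound is needed for the effect, a lower number that less compound is needed. In this assay compound 2 reaches only a limit, > 25000 nM. Compound 1 `COc1ccc(NC(=O)Nc2cc(C)nc3ccccc23)cc1OC` likewise gives only the limit of > 25000 nM. Compound 3 `COc1ccc(NC(=O)Nc2cc(C)nc3ccccc23)cc1F` also stops at the limit, > 25000 nM. Since all three sit at the same limit (the limit of > 25000 nM in this assay, at which 3 of the 3 values shown sit), the steps between them cannot be read: a step that the two limits leave unreadable from compound 1 to compound 2, a step that the two limits leave unreadable from compound 1 to compound 3 and a step that the two limits leave unreadable from compound 2 to compound 3. Compound 4 `Cc1cc(NC(=O)Nc2cccc(Cl)c2)c2ccccc2n1` differs from compound 2 by hydrogen in place of methoxy on an aromatic carbon. Among the measured compounds shown here, no measured step bears on removing the methoxy group, and the three unreadable steps supply no size to build on. Compound 4 is therefore expected to remain at or past the same limit, with an estimated 40000 nM (range 15000 nM to 100000 nM) and an expected step that the limit leaves unreadable from compound 2 to compound 4.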

Compound 4, half-maximal effective concentration: 18000 nM
Beside the measured number, compound 4's estimate is 2.2-fold (0.35 log units) above it; the range from low to high includes it.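

With hydrogen in place of methoxy on this aromatic carbon, ortho to the chloro group, this assay yields its first step with a readable floor: an at least 1.3-fold lower number from compound 2 to compound 4 (0.14 log units; that floor lies within the scatter). As far as these compounds go, that floor does not establish a real change at this position, and the true size of the step remains unknown. Compound 4 is the only compound shown that gives a number rather than a limit: the limit of > 25000 nM in this assay, at which 3 of the 4 values shown sit.

The compounds shown leave open how far the step extends beyond its floor. They also leave open how an amine, a hydroxyl or an ethoxy group on this carbon would read.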